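The compounds below may be only part of what the source reports. "The series", "measured", "known", "first", "only" and "open" are said of these compounds alone.

Measured so far in a physicochemical assay, read by spectrophotometry, with a stated time of 6 min (a lower number here means a stronger inhibitor, a higher number a weaker inhibitor), are two compounds:
Compound 1 `O=C(CCc1nc2ccccc2c(=O)[nH]1)N/N=C/c1ccc(Cl)cc1` with 185000000 nM
Compound 2 `COc1cc(/C=N/NC(=O)CCCc2nc3ccccc3c(=O)[nH]2)ccc1O` with 115000000 nM

These two numbers lie within the scatter of each other. Compound 1 therefore stands level with compound 2, and the pair cannot be ranked on this evidence.

The next compound is compound 3 `O=C(CCc1nc2ccccc2c(=O)[nH]1)N/N=C/c1cc(O)c(O)c(O)c1`, which keeps the shared core and the chain of compound 1 and alters only the aromatic group. The change is 3,4,5-trihydroxyphenyl in place of 4-chlorophenyl on a carbon with a double bond to nitrogen and in words it puts 3,4,5-trihydroxyphenyl in place of 4-chlorophenyl on a carbon with a double bond to nitrogen.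

For the measured compounds named here, no measured pair differs in only one place, so the data offer no direct guide to this change. Even so, a move beyond the scatter toward a lower number in this assay is expected, which would mean a stronger inhibitor. This is a judgement, not a measured trend, and the range is kept wide. The expected size of the move is a 7.4-fold lower number from compound 1 to compound 3 (0.87 log units; beyond the scatter) as estimated here. For compound 3 the estimated value is 25000000 nM with an expected range from 5000000 nM to 110000000 nM in this estimate.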

Compound 3, half-maximal inhibitory concentration: 35000000 nM
The estimate for compound 3 lay 1.4-fold (0.15 log units) below the measured number; measured number inside the range.
By their numbers in this assay, from the lowest: compound 3; then compounds 2 and 1 (each within the scatter of the next).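

In this assay, the aromatic group on the carbon with a double bond to nitrogen can change the result on its own: with the shared core and chain of compound 1 held fixed, 3,4,5-trihydroxyphenyl in place of 4-chlorophenyl gives a 5.3-fold lower number from compound 1 to compound 3 (0.72 log units; beyond the scatter), a modest step toward stronger inhibition. For the compounds shown here, the earlier pair could not show this, since compound 1 and compound 2 differ in more than one place, so this is the only change here that can be read in isolation. No supporting measurement accompanies the step, and the reason for it remains unknown.

The change removes the chlorine and adds three hydroxyl groups in one move, so the compounds shown do not separate the loss of one from the gain of the others or reveal whether all three hydroxyl groups matter. Also open, on these data alone, are how an amine or a carboxylic acid on the same aromatic ring would compare, and whether the same exchange would have a similar effect on the chain of compound 2.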